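The compounds below may be only part of what the source reports. "The series", "measured", "known", "first", "only" and "open" are said of these compounds alone.

Measured so far:
compound 1 `CCCCc1ccc(/C=C/C(=O)Nc2ccc3c(c2)OCCO3)cc1` gives 360 nM in a functional assay on CHO cells for inhibition of transient receptor potential cation channel subfamily V member 1 (Homo sapiens); on this read-out lower numbers stand for stronger inhibition and higher numbers for weaker inhibition
compound 2 `O=C(/C=C/c1ccc(Cl)cc1)Nc1ccc2c(c1)OCCO2` gives 250 nM in this assay
compound 3 `O=C(/C=C/c1ccc(F)cc1)Nc1ccc2c(c1)OCCO2` gives 1000 nM in this assay

Compound 3 stands at the highest number of the three, the weakest inhibition in the set. Its nearest neighbour is compound 1, and the step from compound 1 to compound 3 was a 2.8-fold higher number from compound 1 to compound 3 (0.44 log units; beyond the scatter); the step from compound 2 to compound 3 was a 4.0-fold higher number from compound 2 to compound 3 (0.60 log units; beyond the scatter). Between compound 1 and compound 2 the step was a 1.4-fold lower number from compound 1 to compound 2 (0.16 log units; within the scatter), so the butyl and chloro analogues cannot be told apart on this read-out.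

Compound 4 `O=C(/C=C/c1ccc(C(F)(F)F)cc1)Nc1ccc2c(c1)OCCO2` has not yet been measured. Its change from compound 3 is trifluoromethyl in place of fluoro on an aromatic carbon, on a six-membered aromatic ring of carbon only, para to a large group. Both steps that bear on this position, chloro to fluoro and butyl to fluoro, raised the number beyond the scatter, so a group bulkier than fluoro at this place is expected to bring the number down again. The expected step from compound 3 to compound 4 is therefore a 3.3-fold lower number from compound 3 to compound 4 (0.52 log units; beyond the scatter), a modest gain back toward the values of compounds 1 and 2. Compound 4 is estimated at 300 nM, with a range from 120 nM to 750 nM.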

Compound 4, half-maximal inhibitory concentration: 46 nM
Beside the measured number, compound 4's estimate is 6.5-fold (0.81 log units) above it; the measured number lies below the stated range.
By their numbers in this assay, from the lowest: compound 4; then compounds 2 and 1 (each within the scatter of the next); then compound 3.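

In this assay, within the data shown here, the group on an aromatic carbon para to a large group can move the number much further than the earlier compounds showed, with trifluoromethyl in place of fluoro giving the largest step (a 22-fold lower number from compound 3 to compound 4 (1.34 log units; beyond the scatter)). Butyl and chloro, which could not be told apart, do not mark the low end of the range: trifluoromethyl in place of chloro gives a further gain (a 5.4-fold lower number from compound 2 to compound 4 (0.74 log units; beyond the scatter)), and trifluoromethyl in place of butyl does the same (a 7.8-fold lower number from compound 1 to compound 4 (0.89 log units; beyond the scatter)), so among these four compounds the result belongs to trifluoromethyl itself and not merely to any group other than fluoro. Nothing measured here accounts for why trifluoromethyl stands apart from the other three groups.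

As far as these compounds go, whether the gain extends to other groups at this place, such as bromo, nitrile, methoxy or pentafluoroethyl, stays open. From the compounds shown here alone, the shared core and the amide hydrogen are the same in all four compounds, so it is also open whether the trifluoromethyl gain would survive a change there, for instance an added amine or carboxylic acid on the core.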